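This account rests on a few compounds, and the source may have more. Where it says the series, first, only, none or still open, it means among the compounds named here.

Compound 1 `CCCCCCCCn1cc(/C=[N+](\[O-])Cc2ccccc2)nn1` stands at the edge of what a functional assay on A549 cells (Homo sapiens) for inhibition, read by MTT assay, with a stated time of 24 h (on this read-out lower numbers stand for stronger inhibition and higher numbers for weaker inhibition), can report: in this assay compound 1 gives > 100000 nM, a limit rather than a number. Compound 2 `CCCCCCCCCCn1cc(/C=[N+](\[O-])Cc2ccccc2)nn1` gives > 100000 nM, also a limit. Going by the values given here, the only measured step, a step that the two limits leave unreadable from compound 1 to compound 2, cannot be read because of the limit of > 100000 nM in this assay, at which 2 of the 2 values shown sit. Compound 3 `CCCCCCCCn1cc(/C=[N+](\[O-])C(C)(C)C)nn1` differs from compound 1 by tert-butyl in place of benzyl on a double-bonded nitrogen. Among the compounds with values here, no measured step bears on this change, so the numbers give no direction for it. Compound 3 is expected to give 150000 nM, in the range 40000 nM to 600000 nM, most likely again as a limit. The expected step, a step that the limit leaves unreadable from compound 1 to compound 3, is accordingly estimated as none beyond the scatter.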

Compound 3, half-maximal inhibitory concentration: 31300 nM
The estimate for compound 3 lay 4.8-fold (0.68 log units) above the measured number, and the stated range ends above it.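

In this assay, tert-butyl in place of benzyl on the double-bonded nitrogen gives an at least 3.1-fold lower number from compound 1 to compound 3 (0.50 log units; beyond the scatter), so the group at this position can shift the read-out beyond the scatter. Compound 3 is the only compound shown whose value is a number rather than a limit: the limit of > 100000 nM in this assay, at which 2 of the 3 values shown sit.

As far as these compounds go, the step between the two chain lengths cannot be read, so it remains open whether a longer chain would change the number for compound 3. Also open, from the compounds shown here alone, is whether isopropyl or cyclohexyl on this nitrogen would lower the number further.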